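Chloro for methyl on the 4-methylphenyl group

A few compounds are considered here, and "the series" means these few. Any claim that something is new, unique, unknown or untested is made for them only; others in the source may bear on it.

compound 1 `Clc1ccc(-c2cc(-c3ccco3)cc(-c3ccc(Cl)s3)n2)cc1` gives 1080 nM
compound 2 `Clc1ccc(-c2cc(-c3ccoc3)cc(-c3ccco3)n2)s1` gives 1280 nM
compound 3 `Cc1ccc(-c2cc(-c3ccoc3)cc(-c3ccc(Cl)s3)n2)cc1` gives 1170 nM
compound 4 `Clc1ccc(-c2cc(-c3ccoc3)cc(-c3ccc(Cl)s3)n2)cc1` is not yet measured

In a functional assay on HCT-15 cells (Homo sapiens) for cytotoxicity, read by ELISA, with a stated time of 4 days (a lower number here means a stronger inhibitor, a higher number a weaker inhibitor), compound 3 gives 1170 nM and lies within the scatter of both other measured compounds, so the three values form a single narrow band. The change from compound 3 to compound 4 is chloro in place of methyl on an aromatic carbon and reads as 4-methylphenyl to 4-chlorophenyl, on an aromatic carbon of a six-membered aromatic ring of carbon only, para to a large group.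

Among the compounds with values here, no measured step makes this exact exchange. Within the data shown here, the one measured step available is a 1.1-fold lower number from compound 2 to compound 3 (0.04 log units; within the scatter) for 4-methylphenyl in place of furan-2-yl on an aromatic carbon, and it stays within the scatter. Compound 1 already carries the 4-chlorophenyl group and gives 1080 nM within the same band, which offers no sign of a shift tied to that group. The data are few, however, and hold no direct comparison of chloro with methyl.

The expected step in this assay is a 1.1-fold lower number from compound 3 to compound 4 (0.03 log units; within the scatter) and so none beyond the scatter, with no firm direction. For compound 4 the estimated value is 1100 nM with an expected range from 650 nM to 1800 nM in this read-out.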

Compound 4, half-maximal inhibitory concentration: 640 nM
Estimate against measurement, compound 4: 1.7-fold (0.24 log units) above; measured number outside the range, below it.
By their numbers in this assay, from the lowest: compounds 4, 1, 3 and 2 (each within the scatter of the next).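

Direct reading of the exchange at last: in this assay chloro in place of methyl, on an aromatic carbon of a six-membered aromatic ring of carbon only and para to a large group, gives a 1.8-fold lower number from compound 3 to compound 4 (0.26 log units; within the scatter) and so leaves this position without a shift beyond the scatter. Within the data shown here, the two other comparisons with compound 4 agree, with 4-chlorophenyl in place of furan-2-yl giving a 2.0-fold lower number from compound 2 to compound 4 (0.30 log units; within the scatter) and furan-3-yl in place of furan-2-yl giving a 1.7-fold lower number from compound 1 to compound 4 (0.23 log units; within the scatter) as the first reading of that furan exchange, so all four compounds stay connected within the scatter. No accompanying data bear on this result or offer an account of it.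

Methyl and chloro are the only small groups compared here at this position, so whether the flat reading would hold for an amine, a carboxylic acid or a longer chain in their place remains open. Also open, going by these compounds, is whether the exchange of furan-3-yl for furan-2-yl would read the same with 4-methylphenyl in place of 4-chlorophenyl, and whether any change on the shared core moves the number beyond the scatter in this assay at all.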